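Chain Extension on a Urate Transporter Inhibitor Series

The source may report more compounds than this note shows. Statements on the series, on what has been measured and on what is new or still open speak of the compounds shown alone.

The measured compounds and their values:
compound 1 `N#Cc1ccc(Nc2cnccc2SCCCCCCC(=O)O)c2ccccc12`, 5750 nM
compound 2 `N#Cc1ccc(Oc2cnccc2SCC(=O)O)c2ccccc12`, 6970 nM
compound 3 `CN(c1cnccc1SCCCCCCC(=O)O)c1ccc(C#N)c2ccccc12`, 4640 nM

In an assay on HEK293 cells for inhibition of solute carrier family 22 member 12 (Homo sapiens), read by scintillation counting, with stated times of 30 min and 15 min (a lower number here means a stronger inhibitor, a higher number a weaker inhibitor), compound 2 gives 6970 nM, the highest of the three numbers; compound 1 and compound 3 sit within the scatter of it. For the measured compounds named here, the one step that changes a single place, a 1.2-fold lower number from compound 1 to compound 3 (0.09 log units; within the scatter), is within the scatter and concerns methyl in place of hydrogen on the nitrogen, not the acid chain. Compound 4 `N#Cc1ccc(Oc2cnccc2SCCCCCC(=O)O)c2ccccc12` differs from compound 2 by 4-carboxybutyl in place of carboxy on a saturated chain carbon bound to a sulfur. Going by the values given here, no measured pair isolates chain length alone; compound 1 and compound 3, which carry a longer acid chain and a different link between the core and the aromatic ring, give numbers within the scatter of compound 2. On that basis the step to compound 4 is expected to stay within the scatter, a 1.2-fold lower number from compound 2 to compound 4 (0.07 log units; within the scatter). Compound 4 is therefore estimated at 6000 nM in this assay, with a range of 3000 nM to 12000 nM.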

Compound 4, half-maximal inhibitory concentration: 4740 nM
For compound 4 the middle estimate is 1.3-fold (0.10 log units) above the measured one; measured number inside the range.
By their numbers in this assay, from the lowest: compounds 3, 4, 1 and 2 (each within the scatter of the next).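

For the compounds shown here, the acid chain changes on its own here for the first time: in this assay, replacing (carboxymethyl)sulfanyl with (5-carboxypentyl)sulfanyl gives a 1.5-fold lower number from compound 2 to compound 4 (0.17 log units; within the scatter). At this position, then, the longer chain and the short one cannot be told apart in this measurement, so the added length brings no gain or loss beyond the scatter. Nothing available gives a reason for this result.

The compounds shown leave open whether a chain ending in a primary amide or an amine in place of the carboxylic acid would stay within the scatter of these numbers. They also leave open whether the same lengthening would read alike on the core of compound 1, which carries a nitrogen link.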